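A Branched Acid Group on the Amine Nitrogen

A few compounds are considered here, and "the series" means these few. Any claim that something is new, unique, unknown or untested is made for them only; others in the source may bear on it.

In a functional assay on MDA-MB-453 cells (Homo sapiens) for cytotoxicity, read by MTT assay, with a stated time of 72 h (on this read-out higher numbers stand for weaker inhibition and lower numbers for stronger inhibition), compound 3 (`CC1=CCC[C@H]2[C@](C)(CC3=CC(=O)C=C(NCCC(=O)O)C3=O)[C@@H](C)CC[C@]12C`) gives 3310 nM, the lowest of three numbers. Compound 2 (`CSCC[C@H](NC1=CC(=O)C=C(C[C@]2(C)[C@@H](C)CC[C@]3(C)C(C)=CCC[C@@H]23)C1=O)C(=O)O`) gives 25600 nM, and compound 1 (`CC(C)(C)C1=CC(=O)C=C(NCC(=O)O)C1=O`), which has a different core, gives 171000 nM. Compound 4 (`CC1=CCC[C@H]2[C@](C)(CC3=CC(=O)C=C(N[C@@H](C(=O)O)C(C)C)C3=O)[C@@H](C)CC[C@]12C`) has 1-carboxy-2-methylpropyl in place of 2-carboxyethyl on an amine nitrogen. For the measured compounds named here, only one measured step bears on this change: a 7.7-fold lower number from compound 2 to compound 3 (0.89 log units; beyond the scatter), a modest step beyond the scatter, in which 2-carboxyethyl replaced 1-carboxy-3-(methylsulfanyl)propyl. Compound 4 returns to a 1-carboxy group, so the number should rise rather than fall, probably by a similar or somewhat smaller amount. The expected change is a 4.5-fold higher number from compound 3 to compound 4 (0.66 log units; beyond the scatter). The estimate for compound 4 is 15000 nM, within a range of 5000 nM to 40000 nM.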

Compound 4, half-maximal inhibitory concentration: 8010 nM
Beside the measured number, compound 4's estimate is 1.9-fold (0.27 log units) above it; the measured number falls inside the stated range.
By their numbers in this assay, from the lowest: compound 3; then compound 4; then compound 2; then compound 1.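

In this assay, moving from 2-carboxyethyl to the branched 1-carboxy-2-methylpropyl on the amine nitrogen gives a 2.4-fold higher number from compound 3 to compound 4 (0.38 log units; beyond the scatter), so the unbranched acid chain keeps the lower number. The two branched groups also differ from each other: replacing 1-carboxy-3-(methylsulfanyl)propyl with 1-carboxy-2-methylpropyl gives a 3.2-fold lower number from compound 2 to compound 4 (0.50 log units; beyond the scatter), which shows that the side chain on the branched carbon matters. Nothing measured here explains either step.

Still open, on these data alone, is how a longer chain, such as 3-carboxypropyl, would compare on the shared core. Also open, as far as these compounds go, is what an amide in place of the carboxylic acid would do.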